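Aryl swap on the carbon double-bonded to nitrogen

The source may hold more compounds than are shown below. What is called first, only, known or untested is meant among the compounds shown, and "the series" means these compounds.

Values in a functional assay on MGC-803 cells (Homo sapiens) for inhibition, read by MTT assay; on this read-out higher numbers stand for weaker inhibition and lower numbers for stronger inhibition:
compound 1 `Cc1c(C(=O)N/N=C\c2cccc(O)c2O)oc2cccc(O)c12` gives 5030 nM
compound 2 `Cc1c(C(=O)N/N=C\c2cc(Cl)cc(Cl)c2O)oc2cccc(O)c12` gives 4360 nM
compound 3 `Cc1c(C(=O)N/N=C\c2c(O)cccc2F)oc2cccc(O)c12` gives 10800 nM

Compound 1 stands second highest of the three numbers. Compound 2 sits within the scatter of compound 1, so the two cannot be ordered on these values. Compound 3 lies furthest away: a 2.1-fold higher number from compound 1 to compound 3 (0.33 log units; beyond the scatter), a modest rise that is beyond the scatter.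

Compound 4 `Cc1c(C(=O)N/N=C\c2cc(Cl)ccc2O)oc2cccc(O)c12` has not yet been measured in this assay. It departs from compound 1 as follows: 5-chloro-2-hydroxyphenyl in place of 2,3-dihydroxyphenyl on a carbon with a double bond to nitrogen. Among the measured compounds shown here, the only measured step at this place is the one from compound 1 to compound 3, and it moved the number up modestly. For the measured compounds named here, no measured step exchanges a hydroxyl for a chlorine at this place; compound 2, which also carries chlorine and a single hydroxyl on the ring at this place, shows a number within the scatter of compound 1, and the pair gives no resolvable difference. On that basis the change to compound 4 is expected to produce no step beyond the scatter in this assay, in either direction, though compound 3 shows the number can move upward for a related change at the same place.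

Compound 4 is therefore estimated at 5000 nM, with a range from 2500 nM to 10000 nM. The step this estimate implies is expected to be a 1.0-fold lower number from compound 1 to compound 4 (0.00 log units; within the scatter).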

Compound 4, half-maximal inhibitory concentration: 4160 nM
For compound 4 the middle estimate is 1.2-fold (0.08 log units) above the measured one; low and high end bracket the measured number.
By their numbers in this assay, from the lowest: compounds 4, 2 and 1 (each within the scatter of the next); then compound 3.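

In this assay, the swap to 5-chloro-2-hydroxyphenyl gives a 1.2-fold lower number from compound 1 to compound 4 (0.08 log units; within the scatter) and so leaves the number unresolved despite the loss of a hydroxyl from the ring, while the extra chloro of compound 2 also makes no resolvable difference, with a 1.0-fold lower number from compound 2 to compound 4 (0.02 log units; within the scatter) as the step at that aromatic carbon. The one resolved change is a 2.6-fold lower number from compound 3 to compound 4 (0.41 log units; beyond the scatter) in the same assay, which shows that a ring with a single hydroxyl does not by itself raise the number: among these compounds, only the 2-fluoro-6-hydroxyphenyl of compound 3 stands apart, and compounds 1, 2 and 4 go against any wider trend across the ring changes. Nothing available here explains these steps.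

Whether this place needs a hydroxyl at all stays open, since every ring shown carries at least one, and a plain phenyl, a methoxy group, an amine or a carboxylic acid on the ring would test that. All the changes shown sit on this aryl ring, so the methyl and the hydroxyl on the core of compound 1, and the hydrazone linker itself, remain without a step in this series.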